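Working notes on the step from compound 2 to compound 3

A few compounds are considered here, and "the series" means these few. Any claim that something is new, unique, unknown or untested is made for them only; others in the source may bear on it.

Measured so far:
compound 1 `N#CC1=C(NCN2CCCC2)N(c2ccccc2)C(=O)N2CCCCC(N3CCCC3)C12` — 22.9%
compound 2 `N#CC1=C(NCN2CCCCC2)N(c2ccccc2)C(=O)N2CCCCC(N3CCCC3)C12` — 29.7%

In a functional assay on the whole organism (strain albino) for inhibition, with Rattus norvegicus as the target, read by paw edema, with a stated time of 1 h, at a dose of 20 mmol/kg by the intraperitoneal route (a higher number here means more inhibition at the dose given (going by the name of the read-out), a lower number less inhibition), compound 1 gives 22.9%, and compound 2 gives 29.7%. Going by the values given here, of these two numbers compound 2 is the one at the top, yet the single measured step of a number 6.8 percentage points higher from compound 1 to compound 2 (within the scatter) is within the scatter, so compound 1 and compound 2 are not told apart.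

Compound 3 `N#CC1=C(/N=C/c2ccccc2)N(c2ccccc2)C(=O)N2CCCCC(N3CCCC3)C12` has not been measured. Its change from compound 2 is a group of 8 heavy atoms (7 carbon, 1 nitrogen; one six-membered aromatic ring of carbon only) in place of a group of 8 heavy atoms (6 carbon, 2 nitrogen; one six-membered non-aromatic ring with 1 hetero atom), on a double-bonded ring carbon. Among the compounds with values here, the only step measured so far, a number 6.8 percentage points higher from compound 1 to compound 2 (within the scatter), swapped one saturated ring for another inside the group that now leaves, and stayed within the scatter. Within the data shown here, no measured step covers the loss of the hydrogen-bond donor or the entry of the aromatic ring with its double bond, so the direction is unknown and a wide range is kept. The step expected from the estimate is a number 4.7 percentage points lower from compound 2 to compound 3 (within the scatter). Compound 3 is expected to give 25%, between 8% and 45%.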

Compound 3, a percentage reported as inhibition, in the whole organism at one dose (the size of the read-out at that dose, not a potency): 46.5%
Compound 3: middle estimate off by 21.5 percentage points, on the low side; measured number outside the range, above it.
By their numbers in this assay, from the lowest: compounds 1 and 2 (each within the scatter of the next); then compound 3.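

In this assay, the double-bonded ring carbon is a place where a change moves the read-out: the result is a number 16.8 percentage points higher from compound 2 to compound 3 (beyond the scatter), and likewise a number 23.6 percentage points higher from compound 1 to compound 3 (beyond the scatter), whereas the earlier ring swap inside the leaving group gave only a number 6.8 percentage points higher from compound 1 to compound 2 (within the scatter). Both larger steps change several things at once: the hydrogen-bond donor goes, and a six-membered aromatic ring of carbon and a double bond outside aromatic rings enter, so neither step assigns the gain to any one of these. Nothing measured on hand accounts for the gain.

A benzylamino group at this carbon would keep the aromatic ring and the donor without the double bond, and so remains the open comparison. Also open, as far as these compounds go, is whether a pyridine ring in place of the phenyl ring of the entering group holds the number.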